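The source may report more compounds than this note shows. Statements on the series, on what has been measured and on what is new or still open speak of the compounds shown alone.

Measured so far in a functional assay on the whole organism (Ear) for inhibition, with Mus musculus as the target, with a stated time of 30 min, at a dose of 100 mg/kg by the intraperitoneal route; a higher number here means more inhibition at the dose given (going by the name of the read-out), a lower number less inhibition:
compound 1 `Cc1ccc(C(=O)/C=C/c2ccc(/C=N/NC(=O)c3ccccc3)cc2)c(C)c1` gives 0.18%
compound 2 `N=C(N)N/N=C/c1ccc(/C=C/C(=O)c2cccc(Br)c2)cc1` gives 49.7%
compound 3 `O=C(N/N=C/c1ccc(/C=C/C(=O)c2ccc(Cl)cc2Cl)cc1)c1ccncc1` gives 83.8%

Compound 2 stands second highest of the three numbers. Its nearest neighbour is compound 3, whose number lies higher by an amount beyond the usual scatter; its furthest is compound 1, whose number lies lower, again beyond the scatter. Within the data shown here, no two of the three measured compounds differ from each other in one place only, so no single structural step between measured compounds can be read off; the gaps between them tell only what the three values show, and none of them can be tied to one change.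

Compound 4 `N=C(N)N/N=C/c1ccc(/C=C/C(=O)c2ccc(F)cc2)cc1` is the next to be measured in this assay. It differs from compound 2 in one place: 4-fluorophenyl in place of 3-bromophenyl on a carbonyl carbon. There is no measured step of this kind in the series to lean on, so the direction of the change is open. The expected step of a number 0.3 percentage points higher from compound 2 to compound 4 (within the scatter) is therefore set at none beyond the scatter, with wide uncertainty either way. Compound 4 is estimated to give 50%, within a range from 25% to 75%.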

Compound 4, a percentage reported as inhibition, in the whole organism at one dose (the size of the read-out at that dose, not a potency): 90.7%
Compound 4: middle estimate off by 40.7 percentage points, on the low side, outside the stated range (above it).
By their numbers in this assay, from the lowest: compound 1; then compound 2; then compounds 3 and 4 (each within the scatter of the next).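

In this assay, among these compounds, the exchange of 3-bromophenyl for 4-fluorophenyl on a carbonyl carbon, with the rest of the structure unchanged, comes with a number 41 percentage points higher from compound 2 to compound 4 (beyond the scatter) and is the first step that ties a shift in the read-out to one place. The aryl group on this carbonyl carbon is therefore a place where inhibition at this dose can respond strongly, even though the counted features of the two groups differ only in the halogen: both have the same number of heavy atoms, the same ring and no hydrogen-bond donors or acceptors. No measurement at hand bears on why this step arises.

As far as these compounds go, whether the step belongs to the change of halogen, to its place on the ring or to both remains open, as the two change together in this single pair. Plain phenyl or a methoxyphenyl group on the same carbonyl carbon would show whether any halogen is needed here at all.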